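A few compounds are considered here, and "the series" means these few. Any claim that something is new, unique, unknown or untested is made for them only; others in the source may bear on it.

Among the compounds with values here, compound 1 `C=CCN(C)/N=N/c1n[nH]cc1C(N)=O` and compound 2 `CCOC(=O)c1nc(C)[nH]c1/N=N/N(C)C` are the two members with a number so far. In a functional assay on L1210 cells (Mus musculus) for antiproliferative activity (a lower number here means a less potent compound, a higher number a more potent compound, by a factor of ten per unit of this negative logarithm), compound 1 gives 3.77, the higher of the two values; in this assay compound 2 gives 3.35, and the gap between these two lies beyond the usual scatter, though the two compounds differ in both core and side chain, so the values can be compared only as they stand.

Compound 3 `CCCCN(C)/N=N/c1n[nH]cc1C(N)=O` is not yet measured. It differs from compound 1 by one change: propyl in place of vinyl on a saturated chain carbon bound to an amine nitrogen. Within the data shown here, nothing in the measured pair shows what such a change does, and no step between measured compounds is available. For compound 3 the step of a number 0.03 log units higher from compound 1 to compound 3 (within the scatter) is expected to be small, in no clear direction, within the scatter. Compound 3 is estimated at 3.8, with a range from 3.3 to 4.3.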

Compound 3, logarithm of the reciprocal of the active concentration, log(1/C): 3.81
The estimate for compound 3 lay 0.01 log units below the measured number; the measured number falls inside the stated range.
By their numbers in this assay, from the lowest: compound 2; then compounds 1 and 3 (each within the scatter of the next).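

In this assay, butyl in place of allyl on a saturated chain carbon bound to an amine nitrogen gives a number 0.04 log units higher from compound 1 to compound 3 (within the scatter) and so separates neither chain from the other. Within the data shown here, this is the only step at this place so far, and it shows that removing the double bond outside aromatic rings and adding one carbon, taken together, give no readable difference here. No measurement at hand bears on why this step is so small.

On these data alone, whether a longer chain such as hexyl, or a chain ending in an amine or a carboxylic acid, would stand apart from compound 1 and compound 3 remains open. Also open, as far as these compounds go, is whether butyl would give a similar result on the core of compound 2, which differs from these two compounds in more than one place.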